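A few compounds are considered here, and "the series" means these few. Any claim that something is new, unique, unknown or untested is made for them only; others in the source may bear on it.

Compound 2 has the structure `Cc1ccc(-c2cn(Cc3ccccc3)nn2)cc1` and, in a functional assay on DLD-1 cells (Homo sapiens) for antiproliferative activity, read by MTT assay, with a stated time of 72 h (a lower number here means a stronger inhibitor, a higher number a weaker inhibitor), gives 102000 nM. Going by the values given here, of the two numbers measured so far it is the lower, but the only neighbour, compound 1 with structure `COc1ccc(-c2cn(Cc3ccccc3)nn2)cc1` and a value of 139000 nM, lies within the scatter of it, so the two cannot be ranked. Among the compounds with values here, the one measured step, a 1.4-fold lower number from compound 1 to compound 2 (0.13 log units; within the scatter), exchanges one small group for another on the aromatic carbon that faces the core.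

Compound 3, with structure `FC(F)(F)c1ccc(-c2cn(Cc3ccccc3)nn2)cc1`, has not been measured. Its change from compound 2 is trifluoromethyl in place of methyl on an aromatic carbon, placed on an aromatic carbon of a six-membered aromatic ring of carbon only, para to a large group. Within the data shown here, the same place has already accepted one swap of a small group without a shift beyond the scatter, in the step from compound 1 to compound 2, and that is the only guidance available. The expected step from compound 2 to compound 3 is therefore small, a 1.2-fold lower number from compound 2 to compound 3 (0.08 log units; within the scatter), with no clear direction. For compound 3 in this assay the estimate is 85000 nM, within a range from 30000 nM to 250000 nM.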

Compound 3, half-maximal inhibitory concentration: 74300 nM
Beside the measured number, compound 3's estimate is 1.1-fold (0.06 log units) above it; the measured number falls inside the stated range.
By their numbers in this assay, from the lowest: compounds 3, 2 and 1 (each within the scatter of the next).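

In this assay the aromatic carbon para to a large group has now taken trifluoromethyl, and the exchange for methyl gives a 1.4-fold lower number from compound 2 to compound 3 (0.14 log units; within the scatter) even though the entering group has 4 heavy atoms and the leaving group has 1 heavy atom. The step that joins the other two groups at this place, a 1.9-fold lower number from compound 1 to compound 3 (0.27 log units; within the scatter), also stays inside the scatter, so methyl, methoxy and trifluoromethyl cannot be ranked here and the three compounds read as one group rather than a series. A step of this kind is no larger than repeated measurements of a single compound could produce, so these exchanges show neither a gain nor a loss, and this holds for a larger group as it did for the earlier swap of two small ones.

The compounds shown leave open whether a group of a different kind at this place, such as an amine, a carboxylic acid or a longer chain, would move the number beyond the scatter. No other measurement is at hand that bears on why these three numbers sit so close together.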